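The source may report more compounds than this note shows. Statements on the series, on what has been measured and on what is new or still open speak of the compounds shown alone.

Measured compounds:
Compound 1 `CCNC1=Nc2ccc(Cl)cc2C(C)(C)C1` – 85.1%
Compound 2 `CN(C)CCNC1=Nc2ccc(Cl)cc2C(C)(C)C1` – 50.8%

In a functional assay on MDA-MB-231 cells (Homo sapiens) for cytotoxicity, read by MTT assay, with a stated time of 72 h, tested at 5 uM, in the absence of a further agent (a lower number here means a stronger effect, a higher number a weaker effect of the compound at the concentration tested), compound 1 gives 85.1%, the highest of the two numbers; compound 2 gives 50.8%. Within the data shown here, the one measured step, a number 34.3 percentage points lower from compound 1 to compound 2 (beyond the scatter), puts dimethylamino in place of hydrogen on a saturated chain carbon, two bonds along the chain from an amine nitrogen. Compound 3 `CC1(C)CC(NCc2ccccc2)=Nc2ccc(Cl)cc21` differs from compound 1 by phenyl in place of methyl on a saturated chain carbon bound to an amine nitrogen. Among the measured compounds shown here, no measured step touches that carbon, so the earlier step does not bear directly on it. Compound 3 is therefore expected to show only a modest shift, a number 15.1 percentage points lower from compound 1 to compound 3 (beyond the scatter), with an estimate of 70% and a range from 45% to 92%.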

Compound 3, a percentage reported as activity, at one concentration (the size of the read-out at that concentration, not a potency): 68.1%
Compound 3: middle estimate off by 1.9 percentage points, on the high side; measured number inside the range.
By their numbers in this assay, from the lowest: compound 2; then compound 3; then compound 1.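

In this assay, the carbon bound to the amine nitrogen accepts a second kind of change: ethyl to benzyl also lowers the number, giving a number 17 percentage points lower from compound 1 to compound 3 (beyond the scatter) as its step. Yet phenyl in place of (dimethylamino)methyl at that carbon gives a number 17.3 percentage points higher from compound 2 to compound 3 (beyond the scatter), so here the dimethylamino chain goes with the lower number. No measured evidence explains either shift. The compounds shown leave open how a longer chain ending in dimethylamino, or a pyridine ring in place of phenyl, would read here.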